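The source may report more compounds than this note shows. Statements on the series, on what has been measured and on what is new or still open speak of the compounds shown alone.

Three compounds have been measured in an assay on Sf9 cells for inhibition of protein deacetylase HDAC6 (Homo sapiens), read by fluorescence; on this read-out lower numbers stand for stronger inhibition and higher numbers for weaker inhibition:

compound 1, `O=C(NO)c1ccc(Cn2nnc(Cc3ccccn3)n2)cc1`, gives 25 nM;
compound 2, `Cn1c(Sc2c(F)cc(C(=O)NO)cc2F)nnc1-c1cccs1`, gives 9 nM;
compound 3, `O=C(NO)c1ccc(Nc2nnc(-c3ccccc3)s2)cc1`, gives 66 nM.

Among these three numbers compound 1 stands second highest. Its nearest neighbour is compound 3, whose number is higher by a margin that lies beyond the usual scatter; compound 2 sits furthest away, with a number lower than that of compound 1 by a margin that also exceeds the scatter. Compound 4, `Nc1ccc(-c2nnn(Cc3ccc(C(=O)NO)cc3)n2)cc1`, has not yet been measured in this assay. It is built from the same atoms as compound 1, joined differently: 4-aminophenyl in place of (pyridin-2-yl)methyl on an aromatic carbon. Within the data shown here, no measured pair shows this kind of change, so nothing here tells how large a step it brings or in which direction. Since the hydroxamic acid and the core of compound 1 are kept, and only the group on that aromatic carbon is rearranged, the expectation is a step from compound 1 to compound 4 of a 1.1-fold lower number from compound 1 to compound 4 (0.06 log units; within the scatter), that is, no change beyond the scatter. Compound 4 is therefore estimated at 22 nM in this assay, within a range from 7 nM to 70 nM.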

Compound 4, half-maximal inhibitory concentration: 1 nM
Estimate against measurement, compound 4: 22-fold (1.34 log units) above; the measured number lies below the stated range.
By their numbers in this assay, from the lowest: compound 4; then compound 2; then compound 1; then compound 3.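

The aromatic carbon of the core of compound 1, between two ring nitrogen atoms, turns out to be a sensitive position in this assay: placing 4-aminophenyl there in place of (pyridin-2-yl)methyl brings a 25-fold lower number from compound 1 to compound 4 (1.40 log units; beyond the scatter) and is a large step. The two groups have the same count of heavy atoms, with 6 carbon and 1 nitrogen each, so the way these atoms are joined can matter greatly here even when the atoms themselves stay the same. Nothing available explains why the number falls so far.

This single pair changes three things at once: the entering group has an amine, its ring is of carbon only, and that ring sits directly on the core without the methyl link, so the compounds shown do not tell which of these carries the step. A plain phenyl group or a pyridin-2-yl group at this position would help pull these apart, and a 4-hydroxyphenyl group would show whether the amine can be exchanged for a hydroxyl group.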